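The compounds below may be only part of what the source reports. "The series", "measured", "known", "first", "only" and "open" are said of these compounds alone.

Measured in a functional assay on K562 cells (Homo sapiens) for cytotoxicity, read by MTT assay, with a stated time of 72 h; a lower number here means a stronger inhibitor, a higher number a weaker inhibitor:
Compound 1 `Cc1ccc(-c2ccnc(Nc3ccc(F)cc3)c2)cc1`: 54000 nM
Compound 2 `CCc1ccc(Nc2nc3ccccc3cc2-c2ccccc2)cc1`: 99000 nM
Compound 3 `COc1ccc(Nc2cc(-c3ccc(C)cc3)ccn2)cc1`: 19000 nM

Compound 3 holds the lowest of these three numbers. Compound 4 `COc1ccc(Nc2ccccn2)cc1` differs from it by one change, (hydrogen in place of 4-methylphenyl on an aromatic carbon), hydrogen in place of 4-methylphenyl on an aromatic carbon. Among the compounds with values here, no measured step removes the 4-methylphenyl. Within the data shown here, the only measured step, a 2.8-fold lower number from compound 1 to compound 3 (0.45 log units; beyond the scatter), is a modest one that swaps fluoro for methoxy, so it offers no more than a rough scale. A modest or somewhat larger rise in this assay is therefore expected, towards a weaker inhibitor, though the data cannot exclude no change beyond the scatter. The expected step is a 2.6-fold higher number from compound 3 to compound 4 (0.42 log units; beyond the scatter). For compound 4 the estimated value is 50000 nM, with an expected range of 15000 nM to 150000 nM.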

Compound 4, half-maximal inhibitory concentration: 63000 nM
Estimate against measurement, compound 4: 1.3-fold (0.10 log units) below; low and high end bracket the measured number.
By their numbers in this assay, from the lowest: compound 3; then compounds 1, 4 and 2 (each within the scatter of the next).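

In this assay, replacing the 4-methylphenyl opposite the ring nitrogen with hydrogen gives a 3.3-fold higher number from compound 3 to compound 4 (0.52 log units; beyond the scatter) and so shows that this position, not only the other aromatic ring, affects the number. The 4-methylphenyl therefore counts for something in compound 3, although the step is modest. Nothing at hand accounts for the step.

Only the 4-methylphenyl and hydrogen are shown at this place. On these data alone, whether a methyl group, an unsubstituted phenyl or a phenyl carrying an amine or a carboxylic acid would match or improve on compound 3 remains open.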